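Aryl versus dialkylamino groups on the sulfonyl sulfur

The source may hold more compounds than are shown below. What is called first, only, known or untested is meant among the compounds shown, and "the series" means these compounds.

Among the measured compounds shown here, compound 2 `CCN(CC)S(=O)(=O)c1ccc(NC(=O)NCc2ccncc2)cc1` gives 384 nM in an assay on isolated protein for activation of Nicotinamide phosphoribosyltransferase (Homo sapiens) (on this read-out lower numbers stand for an effect already at smaller amounts and higher numbers for an effect only at larger amounts of compound), the higher of the two numbers measured so far. Compound 1 `O=C(NCc1ccncc1)Nc1ccc(S(=O)(=O)c2ccccc2Cl)cc1` gives 79 nM in this assay. For the measured compounds named here, the only measured step, a 4.9-fold higher number from compound 1 to compound 2 (0.69 log units; beyond the scatter), is the one that bears on the change at hand. Compound 3 `O=C(NCc1ccncc1)Nc1ccc(S(=O)(=O)c2cccc(Cl)c2)cc1` differs from compound 2 by 3-chlorophenyl in place of diethylamino on a sulfonyl sulfur. Going by the values given here, this change largely reverses the step from compound 1 to compound 2, putting a chlorophenyl back on the sulfonyl sulfur, though it is 3-chlorophenyl rather than 2-chlorophenyl, and no measured pair separates those two groups. Compound 3 is therefore expected to move back toward the number of compound 1, by an estimated step of a 3.8-fold lower number from compound 2 to compound 3 (0.58 log units; beyond the scatter) in this assay. Compound 3 is estimated at 100 nM in this assay, with a range of 30 nM to 330 nM that allows for the different chlorophenyl.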

Compound 3, half-maximal effective concentration: 69 nM
Compound 3: middle estimate off by 1.4-fold (0.16 log units), on the high side; the measured number falls inside the stated range.
By their numbers in this assay, from the lowest: compounds 3 and 1 (each within the scatter of the next); then compound 2.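

In this assay, 3-chlorophenyl in place of diethylamino gives a 5.6-fold lower number from compound 2 to compound 3 (0.75 log units; beyond the scatter), so the gap first seen with 2-chlorophenyl recurs with a second chlorophenyl group on the sulfonyl sulfur. Exchanging 2-chlorophenyl for 3-chlorophenyl gives a 1.1-fold lower number from compound 1 to compound 3 (0.06 log units; within the scatter), so these two chlorophenyl groups cannot be told apart in this read-out. No measurement available here accounts for the gap between the chlorophenyl groups and diethylamino.

Still open, on these data alone, is whether the chlorine matters at all, which unsubstituted phenyl or 4-chlorophenyl on the sulfonyl sulfur would test. On the amine side, diethylamino stands alone, so dimethylamino or piperidine would show whether it represents sulfonyl-bound amines generally.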